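Nitrooxy to methyl in an antiproliferative series

A few compounds are considered here, and "the series" means these few. Any claim that something is new, unique, unknown or untested is made for them only; others in the source may bear on it.

Measured so far:
- compound 1 (`O=C(Nc1ccccc1)c1ccc(CCl)cc1`): 900 nM
- compound 2 (`O=C(Nc1ccccc1)c1ccc(CO[N+](=O)[O-])cc1`): 800 nM

Both values come from a functional assay on SW480 cells (Homo sapiens) for antiproliferative activity, read by CCK-8 assay and cell counting, with a stated time of 72 h (a lower number here means a stronger inhibitor, a higher number a weaker inhibitor), and lie within the scatter of each other, so compound 2 stands level with compound 1 on the numbers available. Among the compounds with values here, the only measured step is a 1.1-fold lower number from compound 1 to compound 2 (0.05 log units; within the scatter).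

Compound 3 (`CCc1ccc(C(=O)Nc2ccccc2)cc1`) is still to be measured in this assay. The change from compound 2 is methyl in place of nitrooxy on a saturated chain carbon bound to an aromatic carbon, so that (nitrooxy)methyl becomes ethyl on the shared core.

Within the data shown here, the one measured step, a 1.1-fold lower number from compound 1 to compound 2 (0.05 log units; within the scatter), exchanged chloro for nitrooxy at this same carbon. Among the measured compounds shown here, it shows that swap leaving the number within the scatter, but no compound yet carries methyl there, so it gives only weak guidance. For the measured compounds named here, no step clearly beyond the scatter is expected, with a lean towards a higher number and a range left wider on the high side. The expected change is a 1.9-fold higher number from compound 2 to compound 3 (0.27 log units; within the scatter), an estimate resting on this single step. For compound 3 the estimated value is 1500 nM, with an expected range from 500 nM to 6000 nM in this measurement.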

Compound 3, half-maximal inhibitory concentration: > 100000 nM
Compound 3: a limit, no number; the forecaster's own chance of this, stated with the estimate: 10%; middle value at least 66-fold (1.82 log units) from the limit.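

In this assay compound 3 gives > 100000 nM, which is a limit of the assay and not a number. Methyl in place of nitrooxy on the saturated chain carbon bound to an aromatic carbon gives an at least 120-fold higher number from compound 2 to compound 3 (2.09 log units; beyond the scatter), and methyl in place of chloro at the same carbon gives an at least 110-fold higher number from compound 1 to compound 3 (2.04 log units; beyond the scatter). Within the data shown here, the only earlier step, a 1.1-fold lower number from compound 1 to compound 2 (0.05 log units; within the scatter), showed no more than that chloro and nitrooxy read level here, whereas the two new steps show that the number at this position depends strongly on the group carried: among the three compounds, activity within the measurable range goes with chloro and nitrooxy, and ethyl in compound 3 does not share it.

The compounds shown leave open which feature common to chloro and nitrooxy goes with the activity, and how a hydroxyl, an amine or a bromo on this same carbon would read. From the compounds shown here alone, with compound 3 at a limit, the full size of both new steps also remains open.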